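Adenosine series: losing the 2-hydroxy-3-methylphenyl group

The source may hold more compounds than are shown below. What is called first, only, known or untested is meant among the compounds shown, and "the series" means these compounds.

For the measured compounds named here, in a functional assay on MCF cells (Homo sapiens) for antiproliferative activity, with a stated time of 72 h (on this read-out lower numbers stand for stronger inhibition and higher numbers for weaker inhibition), compound 2 (`Cc1cccc(CNc2ncnc3c2ncn3[C@@H]2O[C@H](CO)[C@@H](O)[C@H]2O)c1O`) gives 6900 nM, the only actual number so far. Compound 1 (`COc1cccc(CNc2ncnc3c2ncn3[C@@H]2O[C@H](CO)[C@@H](O)[C@H]2O)c1`) stands at a limit, > 166000 nM.

Going by the values given here, only one measured step bears on the next compound: an at least 24-fold lower number from compound 1 to compound 2 (1.38 log units; beyond the scatter). It is large and beyond the scatter, and it put 2-hydroxy-3-methylphenyl in place of 3-methoxyphenyl.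

Compound 3 (`OC[C@H]1O[C@@H](n2cnc3c(NCc4cccc(C(F)(F)F)c4)ncnc32)[C@H](O)[C@@H]1O`) follows from compound 2 through this change: 3-(trifluoromethyl)phenyl in place of 2-hydroxy-3-methylphenyl on a saturated chain carbon bound to a nitrogen on an aromatic ring. Here 3-(trifluoromethyl)phenyl replaces 2-hydroxy-3-methylphenyl on the same saturated chain carbon bound to a nitrogen on an aromatic ring. The group that leaves is therefore the one that came in with an at least 24-fold lower number from compound 1 to compound 2 (1.38 log units; beyond the scatter), and the entering group, like the 3-methoxyphenyl of compound 1, has no hydroxy group. A clear move back towards weaker inhibition is expected, although its size is loose, as trifluoromethyl has not yet been measured in this series.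

The expected change is a 7.2-fold higher number from compound 2 to compound 3 (0.86 log units; beyond the scatter), beyond the scatter. For compound 3 the estimated value in this assay is 50000 nM, within an expected range of 12000 nM to 170000 nM.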

Compound 3, half-maximal inhibitory concentration: > 166000 nM
Compound 3: only a limit was reported; the forecaster's own chance of this, stated with the estimate: 40%; at least 3.3-fold (0.52 log units) between middle value and limit.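

In this assay, the change to 3-(trifluoromethyl)phenyl on the saturated chain carbon bound to a nitrogen on an aromatic ring gives an at least 24-fold higher number from compound 2 to compound 3 (1.38 log units; beyond the scatter), so the gain seen with 2-hydroxy-3-methylphenyl is lost with this second replacement as well. Compound 3 stands at a limit, > 166000 nM. The step between compound 1 and compound 3 cannot be read, and across the three compounds the only actual number belongs to the one group with a hydroxy group, while both groups without one end at the same limit: the limit of > 166000 nM in this assay, at which 2 of the 3 values shown sit.

Still open is whether the hydroxy group or the methyl group of 2-hydroxy-3-methylphenyl carries the difference, as the compounds shown change both together, and the limits give no order between 3-methoxyphenyl and 3-(trifluoromethyl)phenyl. Also open, going by these compounds, is how a phenyl ring carrying an amine or a carboxylic acid in place of that hydroxy group would read in this assay.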